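Iodo Analogue: Nitro in Place of Cyano

The source may hold more compounds than are shown below. What is called first, only, known or untested is meant among the compounds shown, and "the series" means these compounds.

Measured compounds:
- compound 1, `N#Cc1cc(C#Cc2ccccn2)cc([N+](=O)[O-])c1`, in a functional assay on HEK293 cells for antagonist activity at metabotropic glutamate receptor 5 (Rattus norvegicus), read by calcium flux (on this read-out lower numbers stand for stronger inhibition and higher numbers for weaker inhibition), compound 1 gives 1.32 nM
- compound 2, `O=[N+]([O-])c1cc(Br)cc(C#Cc2ccccn2)c1`, compound 2 gives 0.39 nM
- compound 3, `N#Cc1cc(I)cc(C#Cc2ccccn2)c1`, compound 3 gives 0.66 nM

Compound 3 stands second highest of the three numbers; its nearest neighbour is compound 2, with a difference within the scatter, and compound 1 sits a similar small distance on the other side. Compound 4, `O=[N+]([O-])c1cc(I)cc(C#Cc2ccccn2)c1`, is not yet measured. It arises from compound 3 by nitro in place of cyano on an aromatic carbon.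

Among the compounds with values here, two measured steps bear on this change. Swapping the cyano group for a bromo group gave a 3.4-fold lower number from compound 1 to compound 2 (0.53 log units; beyond the scatter), a modest shift. Swapping a nitro group for an iodo group gave a 2.0-fold lower number from compound 1 to compound 3 (0.30 log units; within the scatter), which is within the scatter. Compound 4 also differs from compound 2 only in iodo against bromo, and compounds 2 and 3 lie within the scatter of each other. The change from compound 3 to compound 4 is therefore expected to give at most a small shift, a 1.3-fold lower number from compound 3 to compound 4 (0.12 log units; within the scatter), not clearly beyond the scatter. Compound 4 is estimated at 0.5 nM, with a plausible range from 0.2 nM to 1.3 nM.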

Compound 4, half-maximal inhibitory concentration: 2.09 nM
Compound 4: the middle estimate sits 4.2-fold (0.62 log units) below what was measured; the whole stated range lies below it.
By their numbers in this assay, from the lowest: compounds 2, 3, 1 and 4 (each within the scatter of the next, the first and the last beyond it).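

In this assay, the first direct test of nitro against cyano at this aromatic carbon, with iodo held constant, shows a real loss on exchange, with a 3.2-fold higher number from compound 3 to compound 4 (0.50 log units; beyond the scatter). With nitro held constant, the halogen also matters: iodo in place of bromo gives a 5.4-fold higher number from compound 2 to compound 4 (0.73 log units; beyond the scatter), and iodo in place of cyano gives only a 1.6-fold higher number from compound 1 to compound 4 (0.20 log units; within the scatter), whereas bromo in that same place gave a 3.4-fold lower number from compound 1 to compound 2 (0.53 log units; beyond the scatter). No measurement at hand explains why nitro and iodo together fare worse than these neighbours.

It remains open whether nitro in place of cyano costs as much when bromo is the partner, since the compound carrying both bromo and cyano on the shared core is not among those shown. From the compounds shown here alone, what an amine or a carboxylic acid would give at this aromatic carbon also remains open.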